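The compounds below may be only part of what the source reports. "The series", "measured", "known", "first", "only" and "open" are said of these compounds alone.

Compound 3 `CC1=C(C(=O)Nc2ccccc2Cl)C(c2ccc(Br)cc2)NC(=O)N1` was examined in an ADME assay on Vero cells (Chlorocebus sabaeus) for cytotoxicity, read by XTT assay, with a stated time of 72 h; on this read-out lower numbers stand for higher toxicity in this test and higher numbers for lower toxicity in this test. In this assay compound 3 gives only a limit, > 100000 nM. Compound 2 `CC1=C(C(=O)Nc2ccccc2Cl)C(c2ccccc2Br)NC(=O)N1` likewise gives only a limit in this assay, > 100000 nM. Compound 1 `CC1=C(C(=O)Nc2ccccc2Cl)C(c2ccc(Cl)cc2)NC(=O)N1` is recorded in this assay as "non-toxic" (no number reported), without a number. The step from a step that the two limits leave unreadable from compound 2 to compound 3 cannot be sized because both values sit at the limit of > 100000 nM in this assay, at which 2 of the 3 values shown sit. Compound 4 `CC1=C(C(=O)Nc2ccccc2Cl)C(c2ccc(C)cc2)NC(=O)N1` differs from compound 3 by methyl in place of bromo on an aromatic carbon. For the measured compounds named here, no measured step gives a readable size for such a change, so for compound 4 no step beyond the scatter is expected, estimated as a step that the limit leaves unreadable from compound 3 to compound 4. Compound 4 is therefore expected to give 150000 nM, between 80000 nM and 300000 nM, most likely again reported only as a limit.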

Compound 4, half-maximal cytotoxic concentration: > 100000 nM
Compound 4 ended at the assay's limit (the forecaster's own chance of this, stated with the estimate: 75%); the middle value is on the limit's open side.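

In this assay no step can be read from compound 3 to compound 4 or from compound 2 to compound 4, because their values stop at a limit: the limit of > 100000 nM in this assay, at which 3 of the 4 values shown sit. The compounds shown leave open whether swapping these groups changes toxicity at all.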